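Enantiomer swap in a phenylurea pair, whole-plant read-out

The source may report more compounds than this note shows. Statements on the series, on what has been measured and on what is new or still open speak of the compounds shown alone.

Two compounds of the series have been run in an ADME assay on the whole organism with Oryza sativa as the target, tested at 10 uM; on this read-out higher numbers stand for a weaker effect at the one concentration tested and lower numbers for a stronger effect. Compound 1 `C[C@H](NC(=O)Nc1ccccc1Cl)c1ccccc1` gives 106% in this assay. Compound 2 `C[C@@H](NC(=O)Nc1cc(Cl)ccc1Cl)c1ccccc1` gives 101% in this assay, a number that sits alongside that of compound 1 and within the usual scatter of it, so the two cannot be told apart on these figures. Neither shows a strong effect at the single concentration tested.

Compound 3 `C[C@H](NC(=O)Nc1cc(Cl)ccc1Cl)c1ccccc1` is not yet measured. Against compound 2 its change is the two compounds have the same atoms and bonds and differ only in configuration as drawn: 1 of 1 stereo elements differ; a stereocentre at a saturated chain carbon is drawn R in compound 2 and S in compound 3. Among the measured compounds shown here, no measured pair in the set shows what such a change in configuration does here, so no step beyond the scatter is expected in either direction. The expected step from compound 2 to compound 3 in this assay is a number 2 percentage points higher from compound 2 to compound 3 (within the scatter). Compound 3 is therefore estimated at 103% in this assay, within 90% to 116%.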

Compound 3, a percentage reported as activity, at one concentration (the size of the read-out at that concentration, not a potency): 100%
Beside the measured number, compound 3's estimate is 3 percentage points above it; the measured number falls inside the stated range.
By their numbers in this assay, from the lowest: compounds 3, 2 and 1 (each within the scatter of the next).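

In this assay the stereocentre at the saturated chain carbon now has a measured pair, and going from R to S gives a number 1 percentage points lower from compound 2 to compound 3 (within the scatter), so configuration at this position has no readable effect on these figures. Chloro in place of hydrogen on an aromatic carbon, now seen with the configuration as drawn unchanged, gives a number 6 percentage points lower from compound 1 to compound 3 (within the scatter), so this change also stays inside the scatter. The first of these comparisons reads configuration alone: the fact that compounds 2 and 3 differ only in the configuration as drawn

As far as these compounds go, none of the three compounds shows a strong effect at the single concentration tested in this assay, so it remains open whether configuration matters in a compound with a stronger effect. From the compounds shown here alone, whether an amine, a carboxylic acid or a longer chain on the shared core would move the number beyond the scatter also stays open.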